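The source may hold more compounds than are shown below. What is called first, only, known or untested is meant among the compounds shown, and "the series" means these compounds.

Compound 1 `CCC1=C(O)c2c(oc(-c3ccc(O)cc3)cc2=O)C(CC)(CC)C1=O`: 20.6 uM
Compound 2 `CCC1=C(O)c2c(oc(-c3ccc(SC)cc3)cc2=O)C(CC)(CC)C1=O`: 1.38 uM
Compound 3 `CCC1=C(O)c2c(oc(-c3ccccc3C)cc2=O)C(CC)(CC)C1=O`: 2.41 uM

All three numbers come from a functional assay on KBVIN cells (Homo sapiens) for antiproliferative activity, read by sulforhodamine B assay, with a stated time of 3 days; on this read-out lower numbers stand for an effect already at smaller amounts and higher numbers for an effect only at larger amounts of compound. Compound 3 lies close to one of the other two, with a 1.7-fold higher number from compound 2 to compound 3 (0.24 log units; within the scatter), and far from the remaining one, with an 8.5-fold lower number from compound 1 to compound 3 (0.93 log units; beyond the scatter).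

Compound 4 `CCC1=C(O)c2c(oc(-c3ccc(C)c(F)c3)cc2=O)C(CC)(CC)C1=O` keeps the shared core and changes one group: 3-fluoro-4-methylphenyl in place of 2-methylphenyl on an aromatic carbon. In words, this is 3-fluoro-4-methylphenyl in place of 2-methylphenyl on an aromatic carbon, next to the ring oxygen. Among the measured compounds shown here, no measured step tests a fluorine on this phenyl group or this placing of its methyl, so the evidence is indirect.

For the measured compounds named here, compound 1 is the only measured compound with a hydroxy group, and the other large step away from it is a 15-fold lower number from compound 1 to compound 2 (1.17 log units; beyond the scatter). Compound 4 has no hydroxy group either, so it is expected to resemble compound 2 and compound 3 rather than compound 1. Between those two, one substituted phenyl group replaced another with a 1.7-fold higher number from compound 2 to compound 3 (0.24 log units; within the scatter). A similar exchange is therefore expected to stay within the scatter here. The expected change is a 1.2-fold lower number from compound 3 to compound 4 (0.08 log units; within the scatter). Compound 4 is estimated at 2 uM, with an expected range from 0.7 uM to 6 uM.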

Compound 4, concentration for half-maximal effect: 2.95 uM
Estimate against measurement, compound 4: 1.5-fold (0.17 log units) below; the measured number falls inside the stated range.
By their numbers in this assay, from the lowest: compounds 2, 3 and 4 (each within the scatter of the next, the first and the last beyond it); then compound 1.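

In this assay, the exchange of 2-methylphenyl for 3-fluoro-4-methylphenyl gives a 1.2-fold higher number from compound 3 to compound 4 (0.09 log units; within the scatter), so on this aromatic carbon next to the ring oxygen, a phenyl group carrying both a fluorine and a methyl group gives a number that cannot be told apart from that of compound 3. The same group also stays well clear of the 4-hydroxyphenyl compound (a 7.0-fold lower number from compound 1 to compound 4 (0.84 log units; beyond the scatter)), which makes compound 2, compound 3 and compound 4 three differently substituted phenyl compounds that all have lower numbers than compound 1, though it stands modestly apart from the methylsulfanyl compound (a 2.1-fold higher number from compound 2 to compound 4 (0.33 log units; beyond the scatter)). Nothing measured here gives a reason for any of these steps.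

The fluorine and the shifted methyl group arrive together in compound 4, so the compounds shown cannot separate what each contributes on its own. They also leave open how this position would respond to an amine or a carboxylic acid on the phenyl group, or to a longer chain such as butyl in place of the methyl group.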